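Flipping the single stereocentre of compound 3

A few compounds are considered here, and "the series" means these few. Any claim that something is new, unique, unknown or untested is made for them only; others in the source may bear on it.

Compound 1 `C[C@H](NC1=NS(=O)(=O)c2cccnc2N1)C1CCCCC1` gives 29.2 uM in a functional assay (aorta) with Rattus norvegicus as the target; on this read-out higher numbers stand for an effect only at larger amounts of compound and lower numbers for an effect already at smaller amounts.
Compound 2 `C[C@@H](NC1=NS(=O)(=O)c2cccnc2N1)C1CCCCC1` gives 25.2 uM.
Compound 3 `C[C@@H](NC1=NS(=O)(=O)c2cc(Cl)cnc2N1)C1CCCCC1` gives 3.5 uM.

Compound 3 has the lowest number of the three: the step of a 7.2-fold lower number from compound 2 to compound 3 (0.86 log units; beyond the scatter) lies beyond the scatter, and the gap to compound 1 is larger still. Compound 4 `C[C@H](NC1=NS(=O)(=O)c2cc(Cl)cnc2N1)C1CCCCC1` keeps every atom and bond of compound 3 and changes only the drawn configuration: the two compounds have the same atoms and bonds and differ only in configuration as drawn: 1 of 1 stereo elements differ; a stereocentre at a saturated chain carbon is drawn R in compound 3 and S in compound 4. One measured step matches this swap without the chloro, a 1.2-fold lower number from compound 1 to compound 2 (0.06 log units; within the scatter), which stayed within the scatter, and the evidence there is the fact that compounds 1 and 2 differ only in the configuration as drawn. Accordingly, no step beyond the scatter is expected in this assay, a 1.1-fold higher number from compound 3 to compound 4 (0.06 log units; within the scatter). Compound 4 is therefore estimated at 4 uM, with a range from 1.7 uM to 9.5 uM.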

Compound 4, concentration for half-maximal effect: 3.8 uM
The estimate for compound 4 lay 1.1-fold (0.02 log units) above the measured number; the range from low to high includes it.
By their numbers in this assay, from the lowest: compounds 3 and 4 (each within the scatter of the next); then compounds 2 and 1 (each within the scatter of the next).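

With the chloro in place, a 1.1-fold higher number from compound 3 to compound 4 (0.04 log units; within the scatter) shows that in this assay the drawn configuration at the chain stereocentre still makes no difference beyond the scatter. Chloro in place of hydrogen also lowers the number in the other configuration, where a 7.7-fold lower number from compound 1 to compound 4 (0.89 log units; beyond the scatter) matches the earlier step: the same change on two cores in this assay, a 7.2-fold lower number (0.86 log units; beyond the scatter) from compound 2 to compound 3 and a 7.7-fold lower number (0.89 log units; beyond the scatter) from compound 1 to compound 4, 1.1-fold (0.03 log units) apart, within the scatter of two such steps.

The compounds shown leave open how another group on that aromatic carbon, such as fluoro, methoxy or an amine, would compare with chloro. They also leave open whether configuration would matter with a longer chain on the stereocentre.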